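Cyclopropyl on the amide nitrogen: what to expect

A few compounds are considered here, and "the series" means these few. Any claim that something is new, unique, unknown or untested is made for them only; others in the source may bear on it.

In an assay on HEK293 cells for agonist activity at transient receptor potential cation channel subfamily M member 8 (Homo sapiens), read by fluorescence and calcium flux, with a stated time of 15 min (on this read-out lower numbers stand for an effect already at smaller amounts and higher numbers for an effect only at larger amounts of compound), compound 1 `Cc1ccc(OCC(=O)N(Cc2cccs2)c2cccnc2)cc1` gives 198 nM, compound 2 `Cc1ccc(OCC(=O)N(Cc2cccs2)C2COC2)cc1` gives 23000 nM and compound 3 `Cc1ccc(OCC(=O)N(Cc2cccs2)c2cnn(C)c2)cc1` gives 63000 nM. Compound 3 therefore carries the highest number of the three, with a 320-fold higher number from compound 1 to compound 3 (2.50 log units; beyond the scatter) and a 2.7-fold higher number from compound 2 to compound 3 (0.44 log units; beyond the scatter). Compound 4 `Cc1ccc(OCC(=O)N(Cc2cccs2)C2CC2)cc1` differs from compound 3 by cyclopropyl in place of 1-methyl-1H-pyrazol-4-yl on an amide-type nitrogen. The step of a 2.7-fold higher number from compound 2 to compound 3 (0.44 log units; beyond the scatter) bears most on this change, oxetan-3-yl and cyclopropyl both being non-aromatic rings on that nitrogen, while a 320-fold higher number from compound 1 to compound 3 (2.50 log units; beyond the scatter) shows how far either group sits from pyridin-3-yl in this assay. A modest move towards a lower number is expected for compound 4, a 2.5-fold lower number from compound 3 to compound 4 (0.40 log units; beyond the scatter). Compound 4 is estimated at 25000 nM, within a range of 6000 nM to 100000 nM.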

Compound 4, half-maximal effective concentration: 8 nM
Beside the measured number, compound 4's estimate is 3100-fold (3.49 log units) above it, outside the stated range (below it).
By their numbers in this assay, from the lowest: compound 4; then compound 1; then compound 2; then compound 3.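

Having a non-aromatic ring on the amide-type nitrogen does not by itself set the number: cyclopropyl in place of oxetan-3-yl gives a 2900-fold lower number from compound 2 to compound 4 (3.46 log units; beyond the scatter), although both rings are non-aromatic. Cyclopropyl also outdoes both aromatic groups, with a 25-fold lower number from compound 1 to compound 4 (1.39 log units; beyond the scatter) and a 7900-fold lower number from compound 3 to compound 4 (3.90 log units; beyond the scatter), so the lowest number of the four belongs to compound 4. Nothing available explains these gaps. From the compounds shown here alone, it remains open whether cyclobutyl, isopropyl or an ethyl chain on that nitrogen would behave like cyclopropyl.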